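The compounds below may be only part of what the source reports. "The series", "measured", "known", "first", "only" and "open" are said of these compounds alone.

Values measured in a functional assay on the whole organism with Canis familiaris (Canis lupus familiaris) as the target (on this read-out higher numbers stand for an effect only at larger amounts of compound and lower numbers for an effect already at smaller amounts), are as follows:

- compound 1 `OC(CSc1[nH]cnc2ncnc1-2)CN1CCN(C(c2ccc(Cl)cc2)c2ccc(Cl)cc2)CC1` gives 0.33 mg/kg
- compound 2 `Cn1cnc2c(SCC(O)CN3CCN(C(c4ccc(F)cc4)c4ccc(F)cc4)CC3)ncnc21` gives 1.9 mg/kg
- compound 3 `CC(=O)OC(CSc1[nH]cnc2ncnc1-2)CN1CCN(C(c2ccc(F)cc2)c2ccc(F)cc2)CC1` gives 0.3 mg/kg

Compound 3 (0.3 mg/kg) sits at the low end of these numbers, where a smaller dose is enough. It cannot be told apart from compound 1 (0.33 mg/kg), since the two lie within the usual scatter of repeated measurements. The number for compound 2 (1.9 mg/kg) is higher than that of compound 3, and this gap is beyond the scatter.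

The next compound is compound 4 `Fc1ccc(C(c2ccc(F)cc2)N2CCN(CCCSc3[nH]cnc4ncnc3-4)CC2)cc1`. It has hydrogen in place of acetoxy on a saturated chain carbon bound to two saturated chain carbons. Among the compounds with values here, no two measured compounds differ in only one place, and none has hydrogen on that carbon, so the data give no direct size for this change. A small rise in the number seems the most likely outcome, with no firm case for a step beyond the scatter. In this assay the expected move is a 1.7-fold higher number from compound 3 to compound 4 (0.22 log units; within the scatter) as a rough estimate. Compound 2 at 1.9 mg/kg shows that numbers in this small set can lie well apart, so the range is kept wide. The expected value for compound 4 is 0.5 mg/kg with an estimated range of 0.15 mg/kg to 1.8 mg/kg for now.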

Compound 4, dose for half-maximal effect: 1.3 mg/kg
Compound 4: the middle estimate sits 2.6-fold (0.41 log units) below what was measured; low and high end bracket the measured number.
By their numbers in this assay, from the lowest: compounds 3 and 1 (each within the scatter of the next); then compounds 4 and 2 (each within the scatter of the next).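

In this assay, putting hydrogen in place of acetoxy on the saturated chain carbon bound to two saturated chain carbons gives a 4.3-fold higher number from compound 3 to compound 4 (0.64 log units; beyond the scatter), so what this carbon carries makes a real difference to the read-out. Within the data shown here, this is the first pair in the set that differs in one place only, and it gives a size for one defined change, where the earlier compounds offered only a spread of numbers that could not be tied to any single group. With acetoxy on this carbon a smaller dose is enough than with hydrogen there, but nothing available explains the shift.

From the compounds shown here alone, a single pair provides only two points at this position, so it remains open whether the gain belongs to acetoxy in particular or would come with other groups on this carbon. Going by these compounds, how a methoxy group, an amine or a longer ester such as propionyloxy would compare at the same place, with the rest of compound 4 kept unchanged, also remains open.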